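Dropping the whole (2-bromobenzyl)sulfanyl arm of compound 1

The source may hold more compounds than are shown below. What is called first, only, known or untested is meant among the compounds shown, and "the series" means these compounds.

Among the compounds with values here, compound 1 `Cc1cc(Nc2cc(-c3ccccc3)[nH]n2)n2nc(SCc3ccccc3Br)nc2n1` is tested in a functional assay on PC-9 cells (Homo sapiens) for inhibition, read by MTT assay, with a stated time of 72 h (a higher number here means a weaker inhibitor, a lower number a stronger inhibitor), where compound 1 gives 5630 nM, the highest of the three numbers measured so far. Compound 2 `Cc1cc(Nc2cc(-c3ccccc3)[nH]n2)n2nc(SCc3ccc(C(F)(F)F)cc3)nc2n1` gives 4240 nM in this assay and compound 3 `Cc1cc(Nc2cc(-c3ccccc3)[nH]n2)n2nc(SCc3cccc4ccccc34)nc2n1` gives 3950 nM. The steps among these three are small: a 1.3-fold lower number from compound 1 to compound 2 (0.12 log units; within the scatter), a 1.4-fold lower number from compound 1 to compound 3 (0.15 log units; within the scatter) and a 1.1-fold lower number from compound 2 to compound 3 (0.03 log units; within the scatter). Each of them swaps only the aryl ring on the saturated chain carbon bound to the sulfur, and none moves the number beyond the scatter.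

Compound 4 `Cc1cc(Nc2cc(-c3ccccc3)[nH]n2)n2ncnc2n1` differs from compound 1 thus: hydrogen in place of (2-bromobenzyl)sulfanyl on an aromatic carbon. Within the data shown here, no measured step removes the whole (2-bromobenzyl)sulfanyl group; the three steps show only that the choice of aryl ring within that group matters little. The change to compound 4 is therefore larger than anything measured, and the data do not fix its direction. With the entire group leaving, a higher number is taken as the more likely outcome, with a wide range. Compound 4 is expected to give about 12000 nM in this assay, with a range from 3000 nM to 50000 nM. The estimated step is a 2.1-fold higher number from compound 1 to compound 4 (0.33 log units; beyond the scatter).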

Compound 4, half-maximal inhibitory concentration: > 50000 nM
Compound 4 ended at the assay's limit; the forecaster's own chance of this, stated with the estimate: 20%; middle value at least 4.1-fold (0.61 log units) from the limit.
By their numbers in this assay, from the lowest: compounds 3, 2 and 1 (each within the scatter of the next). At a limit, above all of these: compound 4.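

The aryl swaps among compound 1, compound 2 and compound 3 all stayed within the scatter, leaving open whether the arm on this aromatic carbon mattered at all. Replacing the whole (2-bromobenzyl)sulfanyl group with hydrogen at this position, between two ring nitrogen atoms, gives an at least 8.8-fold higher number from compound 1 to compound 4 (0.94 log units; beyond the scatter) in this assay, so a substituent here matters far more than the choice of aryl ring within it. Compound 4 stands at a limit of the assay and not at a number: the limit of > 50000 nM in this assay, at which 1 of the 4 values shown sits.

The compounds shown carry either the complete arm or hydrogen, so it stays open whether the sulfur, the chain carbon or the aryl ring accounts for the step. A methylsulfanyl group or an amine at this position would begin to separate these parts.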